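This account rests on a few compounds, and the source may have more. Where it says the series, first, only, none or still open, it means among the compounds named here.

Working notes on the series, read in a functional assay on Jurkat cells (Homo sapiens) for inhibition, read by MTT assay, with a stated time of 72 h; on this read-out higher numbers stand for weaker inhibition and lower numbers for stronger inhibition. Going by the values given here, compound 1 `COc1cc(NC(=O)/C=C/c2cccc(OCc3ccccc3)c2)cc(OC)c1OC` gives 3500 nM, and compound 2 `C=C(Br)C(=O)Nc1cccc(/C=C/C(=O)Nc2cc(OC)c(OC)c(OC)c2)c1` gives 290 nM, the lower of the two numbers so far. Compound 3 `COc1cc(NC(=O)/C=C/c2cccc(N)c2)cc(OC)c1OC` has not yet been measured. Its change from compound 2 is hydrogen in place of (1-bromoethenyl)carbonyl on a nitrogen on an aromatic ring, which reads as ((1-bromoethenyl)carbonyl)amino to amino.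

Among the compounds with values here, only one measured step bears on this: a 12-fold lower number from compound 1 to compound 2 (1.08 log units; beyond the scatter), a large step beyond the scatter, with ((1-bromoethenyl)carbonyl)amino in place of benzyloxy on an aromatic carbon. Within the data shown here, the bearing is partial, since compound 3 keeps the amino nitrogen and carries no benzyloxy, and no compound with a free amino group has a measured value in this assay. Even so, losing the (1-bromoethenyl)carbonyl group is expected to give a large move to a higher number, of roughly the same size as that step in the opposite direction. The expected change is a 16-fold higher number from compound 2 to compound 3 (1.19 log units; beyond the scatter). For compound 3 the estimated value is 4500 nM, with an expected range of 1300 nM to 16000 nM.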

Compound 3, half-maximal inhibitory concentration: 43300 nM
Compound 3: middle estimate off by 9.6-fold (0.98 log units), on the low side; measured number above the stated range.
By their numbers in this assay, from the lowest: compound 2; then compound 1; then compound 3.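

In this assay, hydrogen in place of (1-bromoethenyl)carbonyl on the nitrogen gives a 150-fold higher number from compound 2 to compound 3 (2.17 log units; beyond the scatter), so this group on the nitrogen separates the two compounds by far more than the earlier step between benzyloxy and ((1-bromoethenyl)carbonyl)amino had shown. Amino in place of benzyloxy on the aromatic carbon gives a 12-fold higher number from compound 1 to compound 3 (1.09 log units; beyond the scatter), which places compound 3 above both other compounds in this series, with both new steps beyond the scatter and the benzyloxy compound in the middle of the three. No measured evidence on these compounds accounts for the size of either step.

Still open, on these data alone, is how the large step from the (1-bromoethenyl)carbonyl group divides among its bromine, its double bond and its carbonyl; an acetyl or an acryloyl group on the same nitrogen would begin to separate these parts. Also open, as far as these compounds go, is how far the benzyloxy result extends to other groups on that aromatic carbon, such as a methoxy group or a shorter ether chain.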